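The source may report more compounds than this note shows. Statements on the series, on what has been measured and on what is new or still open speak of the compounds shown alone.

Series notes. In a functional assay (QGY7701 cells, Homo sapiens) for inhibition, read by MTT assay, with a stated time of 48 h (a lower number here means a stronger inhibitor, a higher number a weaker inhibitor), compound 1 `COc1ccc(CNC(=O)/C=C/c2coc3cc(O)ccc3c2=O)cc1` gives 10000 nM and compound 2 `COc1cccc(NC(=O)/C=C/c2coc3cc(OC)ccc3c2=O)c1` gives 39100 nM; compound 2 thus stands highest of the two numbers shown, with compound 1 its nearest neighbour. Compound 3 `O=C(/C=C/c1coc2cc(O)ccc2c1=O)NCc1ccc(F)cc1` gives only a limit in this assay, > 100000 nM. Limit noted: the limit of > 100000 nM in this assay, at which 1 of the 3 values shown sits. Going by the values given here, the single measured step, an at least 10-fold higher number from compound 1 to compound 3 (1.00 log units; beyond the scatter), concerns a different substituent on a different amide group and does not bear directly on the present change. Compound 4 `COc1ccc2c(=O)c(/C=C/C(=O)Nc3ccccc3OC)coc2c1` differs from compound 2 by 2-methoxyphenyl in place of 3-methoxyphenyl on an amide-type nitrogen. Among the compounds with values here, no measured step tests this change, so no step beyond the scatter is expected. Compound 4 is estimated at 35000 nM, range 8000 nM to 100000 nM, an expected step of a 1.1-fold lower number from compound 2 to compound 4 (0.05 log units; within the scatter).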

Compound 4, half-maximal inhibitory concentration: 17600 nM
The estimate for compound 4 lay 2.0-fold (0.30 log units) above the measured number, within the range that was stated.
By their numbers in this assay, from the lowest: compounds 1 and 4 (each within the scatter of the next); then compound 2. At a limit, above all of these: compound 3.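

In this assay, 2-methoxyphenyl in place of 3-methoxyphenyl on an amide-type nitrogen gives a 2.2-fold lower number from compound 2 to compound 4 (0.35 log units; beyond the scatter). Going by these compounds alone, this is the first measured reading of this change: with the same atoms and the same counts on both sides, the placing of the methoxy group on the phenyl ring alters the number for this pair, though only modestly. Nothing measured here accounts for the step.

Going by these compounds, whether the change carries over to a core with a free hydroxyl remains open. So does the effect of an amine or a carboxylic acid in place of the methoxy group on that phenyl ring.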